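The source may hold more compounds than are shown below. What is called first, only, known or untested is meant among the compounds shown, and "the series" means these compounds.

Measured compounds and their values:

Compound 1, `Cc1nn2c(C(C)c3ccc(CC(C)C)cc3)nnc2s1`: 56%
Compound 2, `CC(C)Cc1ccc(C(C)c2nnc3sc(-c4ccc(Br)cc4)nn23)cc1`: 68%
Compound 3, `CC(C)Cc1ccc(C(C)c2nnc3sc(-c4ccc([N+](=O)[O-])cc4Cl)nn23)cc1`: 67%

In a functional assay on the whole organism (strain Wistar albino) for inhibition, with Rattus norvegicus as the target, read by paw edema, with stated times of 30 min and 2.5 h, at a dose of 20 mg/kg by the oral route (on this read-out higher numbers stand for more inhibition at the one dose given (going by the name of the read-out) and lower numbers for less inhibition), compound 3 stands second highest of the three numbers; its nearest neighbour is compound 2, a step of a number 1 percentage points lower from compound 2 to compound 3 (within the scatter), and its furthest is compound 1, from which it is separated by a number 11 percentage points higher from compound 1 to compound 3 (beyond the scatter).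

The unmeasured compound 4, `CC(C)Cc1ccc(C(C)c2nnc3sc(-c4ccco4)nn23)cc1`, differs from compound 3 in one place: furan-2-yl in place of 2-chloro-4-nitrophenyl on an aromatic carbon.

Among the measured compounds shown here, two measured steps bear on this change. Replacing methyl by an aromatic ring on that carbon gave a number 12 percentage points higher from compound 1 to compound 2 (beyond the scatter) and a number 11 percentage points higher from compound 1 to compound 3 (beyond the scatter), so an aromatic substituent at this position is what separates compound 1 from the other two. Exchanging one aromatic ring for another gave a number 1 percentage points lower from compound 2 to compound 3 (within the scatter), within the scatter. The furan-2-yl ring of compound 4 keeps an aromatic ring in that place, though a smaller five-membered one. Compound 4 is therefore expected to stay close to compound 3 in this assay, with a step of a number 4 percentage points lower from compound 3 to compound 4 (within the scatter) that is not expected to exceed the scatter. The estimate for compound 4 is 63%, within a range from 52% to 74%.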

Compound 4, a percentage reported as inhibition, in the whole organism at one dose (the size of the read-out at that dose, not a potency): 61%
The estimate for compound 4 lay 2 percentage points above the measured number, within the range that was stated.
By their numbers in this assay, from the lowest: compounds 1, 4, 3 and 2 (each within the scatter of the next, the first and the last beyond it).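

In this assay the furan-2-yl ring cannot be told apart from any of the three earlier groups: its step is a number 6 percentage points lower from compound 3 to compound 4 (within the scatter) against 2-chloro-4-nitrophenyl and a number 7 percentage points lower from compound 2 to compound 4 (within the scatter) against 4-bromophenyl, but also a number 5 percentage points higher from compound 1 to compound 4 (within the scatter) against methyl. The earlier compounds shown here showed only six-membered aromatic rings, both beyond the scatter of methyl, whereas compound 4 shows that an aromatic ring on this carbon does not by itself give a step beyond the scatter when it is a five-membered ring with one hetero atom. Nothing measured here explains where compound 4 falls.

The compounds shown do not separate ring size from the hetero atom or from the bromine, chlorine and nitro substituents, a question that an unsubstituted phenyl, a thiophen-2-yl or a pyridyl ring on this carbon could address. They also leave open how this position responds to a group without a ring, such as an amine or a longer alkyl chain, and how the read-out behaves at any other dose.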